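This account rests on a few compounds, and the source may have more. Where it says the series, first, only, none or still open, it means among the compounds named here.

Measured so far:
Compound 1 `O=C1C=C(NCc2ccccc2)C(=O)c2c1nc1n2[C@H]2OC[C@@H](O)[C@H]2OC1`: 2670 nM
Compound 2 `COc1cccc(NC2=CC(=O)c3nc4n(c3C2=O)[C@H]2OC[C@@H](O)[C@H]2OC4)c1`: 1780 nM
Compound 3 `O=C1C=C(Nc2ccc(C(F)(F)F)cc2)C(=O)c2c1nc1n2[C@H]2OC[C@@H](O)[C@H]2OC1`: 2820 nM

All three were run in a functional assay on MGC-803 cells (Homo sapiens) for inhibition, read by sulforhodamine B assay; on this read-out higher numbers stand for weaker inhibition and lower numbers for stronger inhibition. The compounds share one core and differ only in the group on the amine nitrogen. Compound 3 gives the highest of the three numbers, but its steps to the others are small, a 1.1-fold higher number from compound 1 to compound 3 (0.02 log units; within the scatter) and a 1.6-fold higher number from compound 2 to compound 3 (0.20 log units; within the scatter), so on these numbers compound 3 cannot be set apart from compound 1 or compound 2.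

Compound 4 `O=C1C=C(Nc2cccc(Cl)c2)C(=O)c2c1nc1n2[C@H]2OC[C@@H](O)[C@H]2OC1` has not yet been measured in this assay. Its change from compound 3: 3-chlorophenyl in place of 4-(trifluoromethyl)phenyl on an amine nitrogen. For the measured compounds named here, the steps that bear on this are the swap of one substituted phenyl for another, a 1.6-fold higher number from compound 2 to compound 3 (0.20 log units; within the scatter), and the two swaps away from benzyl, a 1.5-fold lower number from compound 1 to compound 2 (0.18 log units; within the scatter) and a 1.1-fold higher number from compound 1 to compound 3 (0.02 log units; within the scatter). Each stayed within the scatter, so changing the group on this nitrogen has so far moved this assay by little. No step beyond the scatter is therefore expected for compound 4 in either direction. The estimated step is a 1.2-fold lower number from compound 3 to compound 4 (0.07 log units; within the scatter). The expected value for compound 4 in this assay is 2400 nM, within 1200 nM to 5000 nM.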

Compound 4, half-maximal inhibitory concentration: 1770 nM
The estimate for compound 4 lay 1.4-fold (0.13 log units) above the measured number; the measured number falls inside the stated range.
By their numbers in this assay, from the lowest: compounds 4, 2, 1 and 3 (each within the scatter of the next).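

Working from this assay, the step with 3-chlorophenyl in place of 4-(trifluoromethyl)phenyl on the amine nitrogen gives a 1.6-fold lower number from compound 3 to compound 4 (0.20 log units; within the scatter) and the step with chloro in place of methoxy on an aromatic carbon gives a 1.0-fold lower number from compound 2 to compound 4 (0.00 log units; within the scatter), so a chlorine-bearing ring, new to the series, leaves the read-out within the scatter of both earlier substituted phenyls. The step with 3-chlorophenyl in place of benzyl gives a 1.5-fold lower number from compound 1 to compound 4 (0.18 log units; within the scatter) and also stays within the scatter, which extends the flat picture at this nitrogen to four groups: benzyl and three different substituted phenyl rings. No measurement in hand accounts for this flat response.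

Still open, on these data alone, is whether anything on this nitrogen can produce a step beyond the scatter, for example a phenyl ring carrying a carboxylic acid, or a longer chain ending in an amine. Also open, as far as these compounds go, is whether a 4-chlorophenyl group reads the same as 3-chlorophenyl, and whether changes to the shared core move the read-out more than changes at this nitrogen.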